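Adding a methoxycarbonylmethyl group to the indole nitrogen

The source may hold more compounds than are shown below. What is called first, only, known or untested is meant among the compounds shown, and "the series" means these compounds.

Measured compounds:
compound 1 `COc1ccccc1N1CCN(C(=O)CCc2c(-c3ccc(Cl)cc3)[nH]c3ccc(C)cc23)CC1` — 0.6 nM
compound 2 `COc1ccccc1N1CCN(C(=O)CCc2c(-c3ccc(Cl)cc3)[nH]c3ccc(Cl)cc23)CC1` — 0.89 nM

In an assay on CHO cells for displacement of a labelled ligand from Substance-P receptor (Homo sapiens) (a higher number here means a weaker inhibitor, a lower number a stronger inhibitor), compound 2 gives the highest of the two numbers, with compound 1 the nearest, and a 1.5-fold higher number from compound 1 to compound 2 (0.17 log units; within the scatter) lies within the scatter. Compound 3 `COC(=O)Cn1c(-c2ccc(Cl)cc2)c(CCC(=O)N2CCN(c3ccccc3OC)CC2)c2cc(Cl)ccc21` carries a different kind of change: (methoxycarbonyl)methyl in place of hydrogen on an aromatic nitrogen. Among the measured compounds shown here, no measured step touches the aromatic nitrogen, so the only guide is that the shared core has so far tolerated a small change without a clear shift. A modest weakening is expected for compound 3, a 2.8-fold higher number from compound 2 to compound 3 (0.45 log units; beyond the scatter), with an estimated 2.5 nM (range 0.7 nM to 9 nM).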

Compound 3, half-maximal inhibitory concentration: 15 nM
Compound 3: middle estimate off by 6.0-fold (0.78 log units), on the low side, and the stated range ends below it.
By their numbers in this assay, from the lowest: compounds 1 and 2 (each within the scatter of the next); then compound 3.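

In this assay, the aromatic nitrogen proves far less forgiving than the aromatic carbon that differs between compound 1 and compound 2: putting (methoxycarbonyl)methyl in place of hydrogen there gives a 17-fold higher number from compound 2 to compound 3 (1.23 log units; beyond the scatter). Nothing available explains why this change costs so much. The change removes the hydrogen and adds the chain in one step, so the compounds shown cannot separate those two events. Also open, from the compounds shown here alone, is whether a plain methyl on this nitrogen, or a carboxylic acid in place of the ester, would give a step of similar size.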